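Swapping the Ring-Nitrogen Substituent of Compound 1

The source may hold more compounds than are shown below. What is called first, only, known or untested is meant among the compounds shown, and "the series" means these compounds.

Compound 1 `NC(=O)c1c(NC(=O)c2ccccc2Cl)sc2c1CCN(Cc1c(Cl)cccc1Cl)C2` gives 4850 nM in a functional assay on HL-60 cells (Homo sapiens) for antiproliferative activity, with a stated time of 24 h (on this read-out higher numbers stand for weaker inhibition and lower numbers for stronger inhibition), the lower of the two numbers recorded. Compound 2 `NC(=O)c1c(NC(=O)c2ccccc2F)sc2c1CCN(Cc1c(Cl)cccc1Cl)C2` gives 10300 nM in this assay. For the measured compounds named here, the only measured step, a 2.1-fold higher number from compound 1 to compound 2 (0.33 log units; beyond the scatter), concerns the halogen on the benzamide ring and not the ring nitrogen. Compound 3 `NC(=O)c1c(NC(=O)c2ccccc2Cl)sc2c1CCN(C(=S)Nc1cccnc1)C2` differs from compound 1 by a group of 9 heavy atoms (6 carbon, 2 nitrogen, 1 sulfur; one six-membered aromatic ring with 1 hetero atom) in place of a group of 9 heavy atoms (7 carbon, 2 chlorine; one six-membered aromatic ring of carbon only), on an amine nitrogen in a ring. Going by the values given here, no measured step touches that place, so the change has no anchor in the data; the account nonetheless expects a 1.2-fold higher number from compound 1 to compound 3 (0.09 log units; within the scatter), with a wide margin. Compound 3 is estimated at 6000 nM in this assay, between 1500 nM and 25000 nM.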

Compound 3, half-maximal inhibitory concentration: 33900 nM
Beside the measured number, compound 3's estimate is 5.7-fold (0.75 log units) below it, outside the stated range (above it).
By their numbers in this assay, from the lowest: compound 1; then compound 2; then compound 3.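

The amine nitrogen in a ring proves to be a place that responds in this assay: exchanging the 2,6-dichlorobenzyl group for the group with the six-membered aromatic ring with 1 hetero atom gives a 7.0-fold higher number from compound 1 to compound 3 (0.84 log units; beyond the scatter). Equal heavy-atom counts in the leaving and entering groups therefore did not keep the number in place. No available measurement accounts for this step.

The compounds shown leave open whether a plain benzyl group or an ethyl chain on this nitrogen would stay nearer compound 1 or compound 3.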